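A few compounds are considered here, and "the series" means these few. Any claim that something is new, unique, unknown or untested is made for them only; others in the source may bear on it.

Measured so far:
compound 1 `CC1CCN(c2nc(Cl)nc3c2ncn3Cc2ccc(/C=C/C(=O)Nc3ccccc3N)cc2)CC1` — 26.9%
compound 2 `CC(C)n1cnc2c(NCc3ccc(C(=O)Nc4ccccc4N)cc3)nc(Cl)nc21` — 76%

In a functional assay on HCT-116 cells (Homo sapiens) for antiproliferative activity, read by CCK-8 assay, with a stated time of 72 h, tested at 8 uM (a higher number here means a stronger effect of the compound at the concentration tested, a lower number a weaker effect), compound 1 gives 26.9%, the lowest of the two numbers recorded; compound 2 sits higher at 76%, a gap beyond the usual scatter, though the two differ in several places, so no single step can be read from them.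

Compound 3 `Nc1ccccc1NC(=O)/C=C/c1ccc(Cn2cnc3c(NC4CCCCC4)nc(Cl)nc32)cc1` is not yet measured. It differs from compound 1 in one place: cyclohexylamino in place of 4-methylpiperidin-1-yl on an aromatic carbon — cyclohexylamino in place of 4-methylpiperidin-1-yl on an aromatic carbon. For the measured compounds named here, with no step of this kind recorded, a modest upward move in this assay is expected for compound 3, a number 15.1 percentage points higher from compound 1 to compound 3 (beyond the scatter), but it could also stay within the scatter of compound 1.

Compound 3 is estimated at 42%, with a likely range from 18% to 68%.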

Compound 3, a percentage reported as inhibition, at one concentration (the size of the read-out at that concentration, not a potency): 18.7%
Compound 3: the middle estimate sits 23.3 percentage points above what was measured, within the range that was stated.
By their numbers in this assay, from the lowest: compounds 3 and 1 (each within the scatter of the next); then compound 2.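

In this assay, cyclohexylamino in place of 4-methylpiperidin-1-yl on this aromatic carbon gives a number 8.2 percentage points lower from compound 1 to compound 3 (within the scatter). At this position, then, exchanging the 4-methylpiperidin-1-yl ring for the carbon-only ring with its hydrogen-bond donor leaves the read-out within the scatter, and both compounds stay in the same low band. No accompanying measurement bears on this result.

Still open, on these data alone, is whether morpholin-4-yl or an open-chain amine such as diethylamino at this position would read differently on the core of compound 1.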